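The source may hold more compounds than are shown below. What is called first, only, known or untested is meant among the compounds shown, and "the series" means these compounds.

Compounds measured so far:
compound 1, `CCOC(=O)[C@@H](N)CCC(=O)NCCSC(=O)C(C)(C)C`, 0.167 h
compound 2, `CCCCOC(=O)[C@@H](N)CCC(=O)NCCSC(=O)C(C)(C)C`, 0.167 h
compound 3, `CCCOC(=O)[C@@H](N)CCC(=O)NCCSC(=O)C(C)(C)C`, 0.167 h

In an ADME assay on isolated protein for metabolic stability, with Cocaine esterase (Homo sapiens) as the target (on this read-out higher numbers stand for a longer-lived compound and lower numbers for a shorter-lived compound), compound 1 sits level with compounds 2 and 3, as the steps of no change at the digits printed from compound 1 to compound 2 (within the scatter) and no change at the digits printed from compound 1 to compound 3 (within the scatter) show. Compound 4, `CCOC(=O)[C@@H](N)CCC(=O)NCCSC(C)=O`, differs from compound 1 by methyl in place of tert-butyl on a carbonyl carbon. The measured steps all alter the alkyl chain on the ester oxygen and leave the tert-butyl on the carbonyl carbon next to sulfur untouched, so none of them bears on this change; the data give no guide to its size or direction. The step from compound 1 to compound 4 is therefore expected as no change at the digits printed from compound 1 to compound 4 (within the scatter), with a wide margin. For compound 4 the expected value in this assay is 0.167 h, between 0.05 h and 0.5 h.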

Compound 4, half-life in the Cocaine esterase assay: 0.167 h
Beside the measured number, compound 4's estimate shows no gap at the digits printed; measured number inside the range.
By their numbers in the Cocaine esterase assay, from the lowest: compounds 1, 2, 3 and 4 (each within the scatter of the next).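

In the Cocaine esterase assay, compound 1 gives 0.167 h and compound 4 gives 0.167 h, and methyl in place of tert-butyl on a carbonyl carbon gives no change at the digits printed from compound 1 to compound 4 (within the scatter), extending the flat picture from the alkyl chain on the ester oxygen to this second position. In a physicochemical assay for acid dissociation, using potentiometric titration, at pH 2, compound 1 gives 8.9 and compound 4 gives 8.94, and the same change gives a number 0.04 log units higher from compound 1 to compound 4 (within the scatter). No measured evidence accounts for either result. The compounds shown leave open whether a phenyl group or a primary amine on this carbonyl carbon would stay level. Since all four compounds read alike, they also leave open what change, if any, would shift the half-life.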